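The source may report more compounds than this note shows. Statements on the series, on what has been measured and on what is new or still open speak of the compounds shown alone.

Measured in a functional assay on SK-OV-3 cells (Homo sapiens) for antiproliferative activity, read by MTT assay, with a stated time of 72 h; on this read-out lower numbers stand for stronger inhibition and higher numbers for weaker inhibition:
- compound 1 `O=C(CCc1cccc2c1B(O)OC2)Nc1ccccc1` - 200 nM
- compound 2 `C#Cc1ccc(NC(=O)CCc2cccc3c2B(O)OC3)cc1` - 6300 nM
- compound 3 `C#Cc1ccccc1NC(=O)CCc1cccc2c1B(O)OC2` - 820 nM

Compound 1 holds the lowest of the three numbers, and both steps away from it lie beyond the scatter. Compound 4 `O=C(CCc1cccc2c1B(O)OC2)Nc1cccc(-c2ccc(F)cc2)c1` is not yet measured. It differs from compound 1 as follows: 4-fluorophenyl in place of hydrogen on an aromatic carbon. That is, 4-fluorophenyl stands in place of hydrogen on an aromatic carbon, meta to a large group.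

The nearest evidence is ethynyl in place of hydrogen on an aromatic carbon: a 32-fold higher number from compound 1 to compound 2 (1.50 log units; beyond the scatter) (large) and a 4.1-fold higher number from compound 1 to compound 3 (0.61 log units; beyond the scatter) (modest). Neither step puts a group where compound 4 carries its new one, and ethynyl is a much smaller group, so the guidance is loose. A modest to large rise in the number is expected in this assay. The expected change is a 5.0-fold higher number from compound 1 to compound 4 (0.70 log units; beyond the scatter). For compound 4 the estimated value is 1000 nM, with an expected range of 200 nM to 5000 nM.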

Compound 4, half-maximal inhibitory concentration: 93 nM
Compound 4: middle estimate off by 11-fold (1.03 log units), on the high side; measured number below the stated range.
By their numbers in this assay, from the lowest: compound 4; then compound 1; then compound 3; then compound 2.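

In this assay a hydrogen on this aromatic carbon, meta to a large group, can give way to 4-fluorophenyl, a group of 7 heavy atoms, with the number falling (a 2.2-fold lower number from compound 1 to compound 4 (0.33 log units; beyond the scatter)). Compound 4 therefore goes against the rise seen with ethynyl at the other places (a 32-fold higher number from compound 1 to compound 2 (1.50 log units; beyond the scatter)) and (a 4.1-fold higher number from compound 1 to compound 3 (0.61 log units; beyond the scatter)), so substitution on this ring does not raise the number in every case. No measurement here accounts for the fall.

Open, from the compounds shown here alone, is whether the fluorine contributes, as against plain phenyl. Also open, going by these compounds, is how a methoxy group or an amine would behave on this same carbon.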